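Dropping the Methoxy Group of Compound 1

The source may report more compounds than this note shows. Statements on the series, on what has been measured and on what is new or still open speak of the compounds shown alone.

Compound 1 `COc1cccc(-c2cc([N+](=O)[O-])cc3cc(C(O)(c4ccc(C#N)cc4)c4cncn4C)oc23)c1`: 38.8 nM
Compound 2 `COc1cccc(-c2cc(CO)cc3cc(C(O)(c4ccc(C#N)cc4)c4cncn4C)oc23)c1`: 16.8 nM
Compound 3 `COc1cccc(-c2cc(C(N)=O)cc3cc(C(O)(c4ccc(C#N)cc4)c4cncn4C)oc23)c1`: 8.2 nM

Of the compounds shown here, three sharing one core have been measured in a functional assay on QG-56 cells (Homo sapiens) for antiproliferative activity; on this read-out lower numbers stand for stronger inhibition and higher numbers for weaker inhibition. Compound 1 gives 38.8 nM and stands highest of the three numbers. Compound 2 gives 16.8 nM, and compound 3 gives 8.2 nM. The measured steps are a 2.3-fold lower number from compound 1 to compound 2 (0.36 log units; beyond the scatter), a 4.7-fold lower number from compound 1 to compound 3 (0.68 log units; beyond the scatter) and a 2.0-fold lower number from compound 2 to compound 3 (0.31 log units; beyond the scatter). All three steps exchange the group at the nitro position of the core; the methoxyphenyl substituent is untouched in every one of them.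

Compound 4 `Cn1cncc1C(O)(c1ccc(C#N)cc1)c1cc2cc([N+](=O)[O-])cc(-c3ccccc3)c2o1` differs from compound 1 in another place: hydrogen in place of methoxy on an aromatic carbon. Among the compounds with values here, no measured step bears on this change, so the expectation for compound 4 cannot be drawn from any step in this assay. Within the data shown here, the three known compounds show only that the core tolerates changes at the nitro position while remaining potent. With nothing known about the methoxy group, compound 4 is expected to show a step of a 1.3-fold higher number from compound 1 to compound 4 (0.11 log units; within the scatter), which is taken as no change beyond the scatter, with a wide allowance in either direction. Compound 4 is therefore estimated at 50 nM, within a range from 15 nM to 200 nM.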

Compound 4, half-maximal inhibitory concentration: 1480 nM
Compound 4: middle estimate off by 30-fold (1.47 log units), on the low side, outside the stated range (above it).
By their numbers in this assay, from the lowest: compound 3; then compound 2; then compound 1; then compound 4.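

In this assay, the change from 3-methoxyphenyl to phenyl gives a 38-fold higher number from compound 1 to compound 4 (1.58 log units; beyond the scatter), a far larger step than the exchanges at the nitro position, the largest of which is a 4.7-fold lower number from compound 1 to compound 3 (0.68 log units; beyond the scatter). Within the data shown here, compound 1, compound 2 and compound 3 all keep the methoxy group, so they could show only that the group at the nitro position shifts the number modestly; compound 4 shows that this aromatic carbon matters much more on this read-out, with the loss of just one methoxy group enough to produce the largest step. No measurement shown here explains why removing this group has so large an effect.

As far as these compounds go, it remains open whether the step depends on the methoxy group itself, or whether a hydroxyl, an amine or a fluorine atom on the same carbon would keep the number close to that of compound 1. From the compounds shown here alone, it also remains open whether the same change would cost as much with the carbamoyl group of compound 3 or the hydroxymethyl group of compound 2 in place of the nitro group.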